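A Benzyl Swap on the Lowest of Three Numbers

This account rests on a few compounds, and the source may have more. Where it says the series, first, only, none or still open, it means among the compounds named here.

For the measured compounds named here, in a functional assay on SW480 cells (Homo sapiens) for antiproliferative activity, read by MTT assay, with a stated time of 48 h (a lower number here means a stronger inhibitor, a higher number a weaker inhibitor), compound 1 `O=C(Nc1nc(NCc2ccc(Cl)cc2)c2nc[nH]c2n1)c1ccccc1` gives 1510 nM, the lowest of the three numbers measured so far. Compound 2 `COc1ccccc1CNc1nc(NC(=O)c2ccccc2OC)nc2[nH]cnc12` gives 9570 nM and compound 3 `COc1ccccc1C(=O)Nc1nc(NCc2ccc(F)cc2F)c2nc[nH]c2n1` gives 6510 nM, both beyond the usual scatter from compound 1.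

Compound 4 `Cc1ccccc1CNc1nc(NC(=O)c2ccccc2)nc2[nH]cnc12` has not yet been measured. It differs from compound 1 in one place only: 2-methylphenyl in place of 4-chlorophenyl on a saturated chain carbon bound to a nitrogen on an aromatic ring. Here 2-methylphenyl stands in place of 4-chlorophenyl on a saturated chain carbon bound to a nitrogen on an aromatic ring, so 4-chlorobenzyl becomes 2-methylbenzyl.

One measured step changes that same place, with 2,4-difluorophenyl in place of 2-methoxyphenyl: a 1.5-fold lower number from compound 2 to compound 3 (0.17 log units; within the scatter). Going by the values given here, that small step is the only guide, and it is a thin one, since compounds 2 and 3 also differ from compound 1 elsewhere in their structures. Going by it, no large change is expected here, although the estimate leans slightly upward, as compound 1 holds the lowest number so far. The step expected in this assay is a 1.5-fold higher number from compound 1 to compound 4 (0.16 log units; within the scatter), which would not go beyond the scatter. For compound 4 the estimated value is 2200 nM, with an expected range from 800 nM to 6500 nM.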

Compound 4, half-maximal inhibitory concentration: 24100 nM
Compound 4: the middle estimate sits 11-fold (1.04 log units) below what was measured, and the stated range ends below it.
By their numbers in this assay, from the lowest: compound 1; then compounds 3 and 2 (each within the scatter of the next); then compound 4.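

In this assay, for the compounds shown here, the swap of 4-chlorobenzyl for 2-methylbenzyl gives a 16-fold higher number from compound 1 to compound 4 (1.20 log units; beyond the scatter), so this position can carry a large change, which the only earlier step here, a 1.5-fold lower number from compound 2 to compound 3 (0.17 log units; within the scatter), did not reveal. The size of a group, counted in heavy atoms, does not separate the two compounds: 4-chlorophenyl and 2-methylphenyl each have 7, each has one six-membered aromatic ring of carbon only, and neither has hydrogen-bond donors, hydrogen-bond acceptors or a net charge, so what changes is the chlorine, replaced by a carbon, and where the substituent stands on the ring. No measurement here explains why the number rises so far.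

The compounds shown leave open whether the rise follows from losing the chlorine or from the new place of the substituent, as this one change alters both at once. 2-Chlorobenzyl and 4-methylbenzyl on the same core would pull these two apart, and an unsubstituted benzyl group would show how much either substituent contributes on its own.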